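Phenoxy to dimethylamino on the pendant aryl ring

The source may report more compounds than this note shows. Statements on the series, on what has been measured and on what is new or still open speak of the compounds shown alone.

Measured compounds:
compound 1, `COc1cc(C)cc(-c2c(-c3ccnc(-c4ccc(C(C)=O)cc4)c3)cnn2CC#N)c1`, -14%
compound 2, `COc1cc(C)cc(-c2nn(CC#N)cc2-c2ccc(-c3cccc(C(C)=O)c3)nc2)c1`, -14%
compound 3, `Cc1cc(O)cc(-c2nn(CC#N)cc2-c2ccnc(-c3ccc(Oc4ccccc4)cc3)c2)c1`, 2%

Of the compounds shown here, three have been tested in a functional assay on NCI-H522 cells (Homo sapiens) for cytotoxicity, read by sulforhodamine B assay, with a stated time of 48 h, tested at 1 uM; on this read-out higher numbers stand for a weaker effect at the one concentration tested and lower numbers for a stronger effect. Compound 1 gives -14% and compound 2 gives -14%; these two values lie within the scatter of each other. Compound 3, with a hydroxy on one aryl ring and a phenoxy on the other, gives 2%, which stands highest of the three numbers; its step to each of compound 1 and compound 2 is beyond the scatter, so compound 3 shows the weakest effect of the three.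

Compound 4, `Cc1cc(O)cc(-c2nn(CC#N)cc2-c2ccnc(-c3ccc(N(C)C)cc3)c2)c1`, has not yet been measured in this assay. Its difference from compound 3 is dimethylamino in place of phenoxy on an aromatic carbon. Among the compounds with values here, no measured pair differs in this place alone, so there is no step to guide the size of this change. Compound 4 is expected to stay near the value of compound 3, giving a step of a number 2 percentage points lower from compound 3 to compound 4 (within the scatter), none beyond the scatter. The estimate for compound 4 in this assay is 0%, within a range from -20% to 20%.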

Compound 4, a percentage reported as activity, at one concentration (the size of the read-out at that concentration, not a potency): -13%
Beside the measured number, compound 4's estimate is 13 percentage points above it, and the stated range covers the measured number.
By their numbers in this assay, from the lowest: compounds 1, 2 and 4 (each within the scatter of the next); then compound 3.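

In this assay, within the data shown here, putting dimethylamino in place of phenoxy on the aromatic carbon gives the first measured step at this position, a number 15 percentage points lower from compound 3 to compound 4 (beyond the scatter) and so toward a stronger effect at the one concentration tested. This shows that the position is not indifferent to the group it carries, and that the six-membered aromatic ring of the phenoxy is not needed for the effect seen with compound 4. Nothing available explains this step.

A single change cannot separate the loss of the phenoxy ring from the arrival of the dimethylamino nitrogen. On these data alone, how a methoxy group, a morpholine ring or a primary amine would read at this position remains open, as does whether the step would hold with the hydroxy on the other aryl ring replaced.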